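Cytotoxicity notes on a chromene series, compound 4 pending

The source may report more compounds than this note shows. Statements on the series, on what has been measured and on what is new or still open speak of the compounds shown alone.

Measured so far in an ADME assay on HeLa cells (Homo sapiens) for cytotoxicity, read by XTT assay, with a stated time of 3 days; a lower number here means that less compound is tolerated, a higher number that more compound is tolerated:
compound 1 `Clc1ccc2c(c1)C=C(/C=C/c1cccnc1)CO2` gives 37500 nM
compound 2 `Clc1ccc2c(c1)C=C(/C=C/c1ccncc1)CO2` gives 75000 nM
compound 3 `C1=C(/C=C\c2cccnc2)COc2ccccc21` gives 37500 nM

The change from compound 1 to compound 2 is pyridin-4-yl in place of pyridin-3-yl on a double-bonded chain carbon bound to a double-bonded chain carbon, and it made a 2.0-fold higher number from compound 1 to compound 2 (0.30 log units; within the scatter). Compound 3 differs from compound 1 in its core; the difference between the two cores is not broken down here. In this assay compound 3 stands level with compound 1 at the digits shown, and against compound 2 the gap is within the scatter.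

Compound 4 `C1=C(/C=C\c2ccncc2)COc2ccccc21` is not yet measured. It differs from compound 3 by pyridin-4-yl in place of pyridin-3-yl on a double-bonded chain carbon bound to a double-bonded chain carbon, the same change as from compound 1 to compound 2, at the same place. The step is expected to resemble a 2.0-fold higher number from compound 1 to compound 2 (0.30 log units; within the scatter), resting on that single precedent, so for compound 4 the expected step is a 2.0-fold higher number from compound 3 to compound 4 (0.30 log units; within the scatter). Compound 4 is estimated at 75000 nM, between 30000 nM and 150000 nM.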

Compound 4, half-maximal cytotoxic concentration: 50000 nM
Compound 4: middle estimate off by 1.5-fold (0.18 log units), on the high side; the measured number falls inside the stated range.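

In this assay, pyridin-4-yl in place of pyridin-3-yl gives a 1.3-fold higher number from compound 3 to compound 4 (0.12 log units; within the scatter) on the core of compound 3. The two steps for this change do not differ on the two cores: the same change on two cores in this assay, a 2.0-fold higher number (0.30 log units; within the scatter) from compound 1 to compound 2 and a 1.3-fold higher number (0.12 log units; within the scatter) from compound 3 to compound 4, 1.5-fold (0.18 log units) apart, within the scatter of two such steps. Within the data shown here, since each step lies within the scatter, the pair shows only that the change stays within the scatter on both cores, not that it has a real effect of its own or that the same would hold on any further core.

Still open, on these data alone, is how this assay responds when something other than a pyridine ring sits on a double-bonded chain carbon bound to a double-bonded chain carbon, such as a phenyl group, an amine or a carboxylic acid. Whether any such group would give a step beyond the scatter cannot be told from these compounds.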